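Mirroring One Ring Carbon in Compound 3

The source may report more compounds than this note shows. Statements on the series, on what has been measured and on what is new or still open speak of the compounds shown alone.

Compound 1 `O=C(CN1CCCC1)N1CCC(NS(=O)(=O)c2cc(S(=O)(=O)c3ccccc3)ccc2C(F)(F)F)CC1` gives 110 nM in an assay on isolated protein for binding affinity to secreted frizzled-related protein 1 (Homo sapiens), read by fluorescence; on this read-out higher numbers stand for weaker inhibition and lower numbers for stronger inhibition.
Compound 2 `O=C(Cn1ccnc1)N1CCC(NS(=O)(=O)c2cc(S(=O)(=O)c3ccccc3)ccc2C(F)(F)F)CC1` gives 30 nM in this assay.
Compound 3 `CC(C)(C)OC(=O)N1CCC[C@H]1C(=O)N1CCC(NS(=O)(=O)c2cc(S(=O)(=O)c3ccccc3)ccc2C(F)(F)F)CC1` gives 60 nM in this assay.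

Of these three numbers, compound 3 holds the second highest. Its nearest neighbour is reached by a 1.8-fold lower number from compound 1 to compound 3 (0.26 log units; within the scatter), its furthest by a 2.0-fold higher number from compound 2 to compound 3 (0.30 log units; within the scatter); both gaps lie within the scatter. Compound 4 `CC(C)(C)OC(=O)N1CCC[C@@H]1C(=O)N1CCC(NS(=O)(=O)c2cc(S(=O)(=O)c3ccccc3)ccc2C(F)(F)F)CC1` keeps every atom and bond of compound 3 and differs only in configuration as drawn: the two compounds have the same atoms and bonds and differ only in configuration as drawn: 1 of 1 stereo elements differ; a stereocentre at a saturated ring carbon is drawn S in compound 3 and R in compound 4. Within the data shown here, no measured step changes a configuration, so none bears directly on this move. Among the measured compounds shown here, the steps that alter the group on the carbonyl carbon, a 1.8-fold lower number from compound 1 to compound 3 (0.26 log units; within the scatter) and a 2.0-fold higher number from compound 2 to compound 3 (0.30 log units; within the scatter), stayed within the scatter, and the only step beyond it, a 3.7-fold lower number from compound 1 to compound 2 (0.56 log units; beyond the scatter), exchanged one group for another rather than mirroring a centre. For the measured compounds named here, with no direct precedent, no step beyond the scatter is expected in this assay. Compound 4 is therefore estimated at 60 nM, with a range from 20 nM to 180 nM. The expected step is no change at the digits printed from compound 3 to compound 4 (within the scatter).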

Compound 4, half-maximal inhibitory concentration: 120 nM
Compound 4: middle estimate off by 2.0-fold (0.30 log units), on the low side, and the stated range covers the measured number.
By their numbers in this assay, from the lowest: compounds 2, 3, 1 and 4 (each within the scatter of the next, the first and the last beyond it).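

Mirroring the stereocentre gives a 2.0-fold higher number from compound 3 to compound 4 (0.30 log units; within the scatter), so the drawn configuration at this saturated ring carbon has no effect that can be told from the scatter, and the reading is clean because nothing else separates the pair: the fact that compounds 3 and 4 differ only in the configuration as drawn. The mirrored form does alter one comparison: replacing (1H-imidazol-1-yl)methyl on the carbonyl carbon now gives a 4.0-fold higher number from compound 2 to compound 4 (0.60 log units; beyond the scatter), whereas compound 3 stayed within the scatter of compound 2. Replacing (pyrrolidin-1-yl)methyl gives a 1.1-fold higher number from compound 1 to compound 4 (0.04 log units; within the scatter), so that comparison stays within the scatter for both mirror forms.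

Still open, going by these compounds, is whether the two mirror forms would stay this close with a free ring amine or an acetyl group in place of tert-butoxycarbonyl. The compounds shown also leave open whether mirroring matters on a six-membered piperidine ring in place of the pyrrolidine.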